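Furanylmethylamino quinazolines: a pyrrolidine tail replaces a butyl chain

A few compounds are considered here, and "the series" means these few. Any claim that something is new, unique, unknown or untested is made for them only; others in the source may bear on it.

Measured compounds:
Compound 1 `CCCCNc1nc(NCc2ccco2)c2ccccc2n1` — 94.8%
Compound 2 `CCCCNc1nc(NCc2ccco2)c2cccc(F)c2n1` — "not determined" (no result reported)

Among the compounds with values here, compound 1 is the only member of this small set with a number in a functional assay on HCT-116 cells (Homo sapiens) for cytotoxicity, read by MTT assay, with a stated time of 2 days, tested at 10 uM; on this read-out lower numbers stand for less inhibition and higher numbers for more inhibition at the one concentration tested (going by the name of the read-out). In this assay compound 1 gives 94.8%, a near-complete response at the single concentration tested, and it therefore stands as the reference point. Compound 2 carries an added fluorine on the shared core, but in this assay compound 2 is recorded as "not determined" (no result reported), so nothing can be said of how it compares.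

Compound 3 `c1coc(CNc2nc(NCCCN3CCCC3)nc3ccccc23)c1` has not yet been measured. It differs from compound 1 in one place: pyrrolidin-1-yl in place of methyl on a saturated chain carbon, three bonds along the chain from a nitrogen on an aromatic ring. The shared core and the furan-bearing arm are unchanged.

Within the data shown here, with no measured pair showing how such a change plays out, the expectation rests on compound 1 alone, whose reading of 94.8% leaves little room for an upward move. The step of a number 6.8 percentage points lower from compound 1 to compound 3 (within the scatter) is expected to be small, within the usual scatter or at most a modest decrease. Compound 3 is accordingly estimated at 88%, with a range from 65% to 99%.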

Compound 3, a percentage reported as inhibition, at one concentration (the size of the read-out at that concentration, not a potency): 67.5%
Compound 3: middle estimate off by 20.5 percentage points, on the high side, within the range that was stated.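

The butyl chain of compound 1 proves not to be a neutral place for change in this assay, as replacing butyl with 3-(pyrrolidin-1-yl)propyl gives a number 27.3 percentage points lower from compound 1 to compound 3 (beyond the scatter) at the one concentration tested. The change does not abolish the read-out, since compound 3 still shows 67.5% in the same test, so a chain ending in a saturated nitrogen-containing ring remains compatible with substantial inhibition here. No measurement accompanying these values accounts for the fall, and this single step cannot separate the contribution of the added ring from that of its nitrogen or of the altered chain.

The effect of the added fluorine on the shared core remains unreadable, as compound 2 has no number to compare, and a single-concentration read-out gives no potency for either measured compound. From the compounds shown here alone, it also remains open whether a piperidine or morpholine ring, an open dimethylamino end, or a shorter or longer chain carrying the same pyrrolidine would follow compound 3 or stay closer to compound 1.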